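A few compounds are considered here, and "the series" means these few. Any claim that something is new, unique, unknown or untested is made for them only; others in the source may bear on it.

Working notes on the series. Compound 3 `CN(c1ccc2[nH]c(-c3n[nH]c4ccccc34)cc2n1)S(=O)(=O)c1ccc(Br)cc1` gives 11500 nM in a functional assay on SMMC-7721 cells (Homo sapiens) for antiproliferative activity, read by MTT assay, with a stated time of 72 h (on this read-out lower numbers stand for stronger inhibition and higher numbers for weaker inhibition), the smallest of the three numbers, with compound 2 `CN(C(=O)c1ccccc1)c1ccc2[nH]c(-c3n[nH]c4ccccc34)cc2n1` at 12500 nM and compound 1 `CN(C(=O)C(C)(C)C)c1ccc2[nH]c(-c3n[nH]c4ccccc34)cc2n1` at 22200 nM, each within the scatter of it. The next step to compound 4 `CN(C(=O)Nc1ccccc1)c1ccc2[nH]c(-c3n[nH]c4ccccc34)cc2n1` is phenylcarbamoyl in place of (4-bromophenyl)sulfonyl on a nitrogen on an aromatic ring. The measured steps at this nitrogen bear on it: a 1.9-fold lower number from compound 1 to compound 3 (0.29 log units; within the scatter) and a 1.1-fold lower number from compound 2 to compound 3 (0.04 log units; within the scatter), neither beyond the scatter, so the substituent at this position has so far moved the numbers little. A step of similar size is expected, without a clear direction, so the estimated change is a 1.1-fold higher number from compound 3 to compound 4 (0.05 log units; within the scatter). Compound 4 is therefore expected near 13000 nM, in the range 5000 nM to 35000 nM.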

Compound 4, half-maximal inhibitory concentration: 280 nM
Estimate against measurement, compound 4: 46-fold (1.67 log units) above; the measured number lies below the stated range.
By their numbers in this assay, from the lowest: compound 4; then compounds 3, 2 and 1 (each within the scatter of the next).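

For the compounds shown here, this nitrogen is less indifferent than the earlier compounds suggested: in this assay the change to phenylcarbamoyl gives a 41-fold lower number from compound 3 to compound 4 (1.61 log units; beyond the scatter) and separates compound 4 from the rest of the series. On the carbonyl carbon, anilino in place of phenyl gives a 45-fold lower number from compound 2 to compound 4 (1.65 log units; beyond the scatter) and anilino in place of tert-butyl gives a 79-fold lower number from compound 1 to compound 4 (1.90 log units; beyond the scatter) so a single change there carries the whole gain. The entering phenylcarbamoyl holds a hydrogen-bond donor that the leaving (4-bromophenyl)sulfonyl lacks.

As far as these compounds go, whether that donor matters stays open, and a benzylamino group or an N-methylanilino group on the carbonyl carbon would test it. No evidence at hand explains the gain.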